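Acylurea pair: carboxy in place of acetyl, cytotoxicity outlook

The compounds below may be only part of what the source reports. "The series", "measured", "known", "first", "only" and "open" are said of these compounds alone.

Compound 1 `CC(=O)c1ccc(NC(=O)Nc2cc(C)nc3ccccc23)cc1` is the reference point for this pair. In an ADME assay on HEK293 cells (Homo sapiens) for cytotoxicity, with a stated time of 72 h (a higher number here means that more compound is needed for the effect, a lower number that less compound is needed), compound 1 gives > 25000 nM, which is a limit of the assay and not a number. Compound 2 `COC(=O)c1cccc(NC(=O)Nc2cc(C)nc3ccccc23)c1` in this assay gives 26000 nM. Compound 1 thus stands at the limit of > 25000 nM in this assay, at which 1 of the 2 values shown sits, the upper edge of what this assay reports, and the two measured compounds show no difference that the data can resolve.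

Compound 3 `Cc1cc(NC(=O)Nc2ccc(C(=O)O)cc2)c2ccccc2n1` is not yet measured in this assay. It differs from compound 1 by hydroxy in place of methyl on a carbonyl carbon. For the measured compounds named here, no measured step runs between the two measured compounds, so the effect of the change cannot be read from this series; with both measured values sitting at the reporting edge, no step beyond the scatter is expected in either direction. The step from compound 1 to compound 3 is expected as a step that the limit leaves unreadable from compound 1 to compound 3. Compound 3 is therefore estimated at 30000 nM in this assay, with a range from 15000 nM to 60000 nM, and most likely the assay will again report only a limit.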

Compound 3, half-maximal effective concentration: > 25000 nM
Compound 3 was reported as a limit; the forecaster's own chance of this, stated with the estimate: 80%; the middle value is on the limit's open side.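

For the compounds shown here, compound 1 and compound 3 are both reported only as limits in this assay, so no step between them can be read: the limit of > 25000 nM in this assay, at which 2 of the 3 values shown sit.

The compounds shown leave open where compound 1 and compound 3 actually fall, and whether carboxy in place of acetyl changes cytotoxicity at all.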